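Acyl-urea aryl swap on a thiazole hydrazone series

A few compounds are considered here, and "the series" means these few. Any claim that something is new, unique, unknown or untested is made for them only; others in the source may bear on it.

Compound 1 `Cc1nc(N(C)C(=O)NC(=O)c2c(F)cccc2F)sc1C(=O)N/N=C/c1ccc(Cl)cc1` gives > 100 ug/mL in a functional assay on HepG2 cells (Homo sapiens) for inhibition, read by MTT assay, with a stated time of 72 h (a lower number here means a stronger inhibitor, a higher number a weaker inhibitor), which is a limit of the assay rather than a number.
Compound 2 `CN(C(=O)NC(=O)c1ccccc1F)c1nc(C(F)(F)F)c(C(=O)N/N=C/c2cc(C(F)(F)F)cc(C(F)(F)F)c2)s1` gives 4.47 ug/mL in this assay.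
Compound 3 `CN(C(=O)NC(=O)c1ccc([N+](=O)[O-])cc1)c1nc(C(F)(F)F)c(C(=O)N/N=C/c2ccc([N+](=O)[O-])cc2)s1` gives 12.3 ug/mL in this assay.

Of the two numbers, compound 2 stands lowest, with compound 3 the nearest and higher, beyond the scatter. Compound 4 `CN(C(=O)NC(=O)c1ccc(C(F)(F)F)cc1)c1nc(C(F)(F)F)c(C(=O)N/N=C/c2cc(C(F)(F)F)cc(C(F)(F)F)c2)s1` has not been measured. It differs from compound 2 by 4-(trifluoromethyl)phenyl in place of 2-fluorophenyl on a carbonyl carbon. Among the compounds with values here, no single-change step between measured compounds is available, so the change is read against compound 2 alone. The expected step from compound 2 to compound 4 is a 1.2-fold higher number from compound 2 to compound 4 (0.09 log units; within the scatter), a change that could fall within the scatter. Compound 4 is therefore estimated at 5.5 ug/mL, with a range from 1.8 ug/mL to 17 ug/mL.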

Compound 4, half-maximal inhibitory concentration: 8.35 ug/mL
Compound 4: the middle estimate sits 1.5-fold (0.18 log units) below what was measured; the range from low to high includes it.
By their numbers in this assay, from the lowest: compounds 2, 4 and 3 (each within the scatter of the next, the first and the last beyond it). At a limit, above all of these: compound 1.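

Within the data shown here, on a carbonyl carbon whose other neighbour is an amide-type nitrogen, 4-(trifluoromethyl)phenyl in place of 2-fluorophenyl gives the first single-change reading in this assay: a 1.9-fold higher number from compound 2 to compound 4 (0.27 log units; within the scatter). The entering group has more heavy atoms than the one that leaves, yet the number stays within the scatter, so at this place this swap makes no clear difference. Nothing measured here gives a reason for this step. The compounds shown leave open whether a phenyl ring carrying an amine or a carboxylic acid would behave the same way. They also do not separate the change of substituent from the change of its ring position, which 4-fluorophenyl or 2-(trifluoromethyl)phenyl would do.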